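A few compounds are considered here, and "the series" means these few. Any claim that something is new, unique, unknown or untested is made for them only; others in the source may bear on it.

In an ADME assay on MT4 cells (Homo sapiens) for cytotoxicity, read by MTT assay, with a stated time of 96 h (on this read-out lower numbers stand for higher toxicity in this test and higher numbers for lower toxicity in this test), three compounds of one series have been measured, all built on the shared core carried by compound 1 `Cc1ccc(NCc2cn(-c3ccccc3)nc2-c2ccc(C(F)(F)F)cc2)cc1`. For compound 1 the read-out is a limit of the test rather than a number: compound 1 gives > 100000 nM. Compound 2 `Cc1ccc(NCc2cn(-c3ccccc3)nc2-c2ccccc2)cc1` likewise returns only a limit, > 100000 nM. The change from compound 2 to compound 1 is trifluoromethyl in place of hydrogen on an aromatic carbon, and the step it made, a step that the two limits leave unreadable from compound 2 to compound 1, cannot be read because both values sit at the limit of > 100000 nM in this assay, at which 3 of the 3 values shown sit.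

Compound 3 `Cc1ccc(-c2nn(-c3ccccc3)cc2CNc2ccccc2)cc1` has the same atoms as compound 2 joined differently; the difference between the two cores is not broken down here. In this assay compound 3 again gives only a limit, > 100000 nM. Compound 4 `Cc1ccc(-c2nn(-c3ccccc3)cc2CNc2ccc(C(F)(F)F)cc2)cc1` has not yet been measured. For the measured compounds named here, it differs from compound 3 by trifluoromethyl in place of hydrogen on an aromatic carbon, which is the same change as the one that separates compound 1 from compound 2.

What to expect rests on two things. Compound 3 sits at a limit, > 100000 nM. The same change, made on the other core, left compound 1 at a limit too, > 100000 nM. For compound 4 in this assay the expected value is therefore 100000 nM, with a range from 50000 nM to 200000 nM, and the expected step is a number no higher from compound 3 to compound 4 (the limit leaves the size open); most likely the test will once more report only a limit for compound 4.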

Compound 4, half-maximal cytotoxic concentration: > 100000 nM
Compound 4: a limit, no number (the forecaster's own chance of this, stated with the estimate: 85%); the middle value sits exactly at the limit.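

In this assay compound 4 returns only a limit, > 100000 nM. The step from compound 3 to compound 4 therefore cannot be read, because both compounds sit at the same limit of the test: the limit of > 100000 nM in this assay, at which 4 of the 4 values shown sit.

The compounds shown leave open whether trifluoromethyl in place of hydrogen on an aromatic carbon changes this read-out at all, on either core, since none of the four gives a number.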